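The compounds below may be only part of what the source reports. "The series", "measured", "known", "first", "only" and "open" are said of these compounds alone.

Three quinone-like compounds sharing the same atoms arranged in two different ways have been tested for how strongly they kill lung cancer cells. Compound 1 `CC(C)(C)C1=CC(=O)C=C(NCc2ccccc2)C1=O` and compound 2 `CCNC1=CC(=O)C=C(C(C)(C)C)C1=O` share one core, while compound 3 `CCNC1=CC(=O)C(C(C)(C)C)=CC1=O` carries the same groups on a core joined differently; the difference between the two cores is not broken down here. In a functional assay on NCI-H460 cells (Homo sapiens) for cytotoxicity, read by MTT assay, with a stated time of 72 h (a higher number here means a weaker inhibitor, a lower number a stronger inhibitor), compound 1 gives 10000 nM and compound 2 gives 14000 nM. Compound 3 gives 65000 nM in this assay, the highest of the three numbers.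

The change from compound 2 to compound 1 is phenyl in place of methyl on a saturated chain carbon bound to an amine nitrogen, and it gave a 1.4-fold lower number from compound 2 to compound 1 (0.15 log units; within the scatter). Compound 4 `CC(C)(C)C1=CC(=O)C(NCc2ccccc2)=CC1=O` carries the same kind of change on the core of compound 3: phenyl in place of methyl on a saturated chain carbon bound to an amine nitrogen. Because the earlier change gave a 1.4-fold lower number from compound 2 to compound 1 (0.15 log units; within the scatter), a similarly small step is expected for compound 4, so that a 1.3-fold lower number from compound 3 to compound 4 (0.11 log units; within the scatter) is estimated. Compound 4 is therefore expected to give about 50000 nM in this assay, somewhere between 20000 nM and 120000 nM.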

Compound 4, half-maximal inhibitory concentration: 15000 nM
Beside the measured number, compound 4's estimate is 3.3-fold (0.52 log units) above it; the measured number lies below the stated range.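

In this assay, putting phenyl in place of methyl on a saturated chain carbon bound to an amine nitrogen gave a 4.3-fold lower number from compound 3 to compound 4 (0.64 log units; beyond the scatter), so on this core the change makes a real difference. Set beside the same change on the other core, the two steps do not match: the same change on two cores in this assay, a 1.4-fold lower number (0.15 log units; within the scatter) from compound 2 to compound 1 and a 4.3-fold lower number (0.64 log units; beyond the scatter) from compound 3 to compound 4, 3.1-fold (0.49 log units) apart, beyond the scatter of two such steps. The size of the step therefore did not carry over unchanged between these two cores, but one change on two cores gives no rule for other cores or other changes, and these numbers do not say why the steps differ.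

The compounds shown leave open whether a longer chain or a carboxylic acid in place of phenyl would also give steps that differ between the two cores. They also leave open whether an amine at that place would follow the same course on both cores.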